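Compound 4: benzoyl in place of (2-chlorophenyl)carbonyl

The compounds below may be only part of what the source reports. "The series", "measured", "known", "first", "only" and "open" are said of these compounds alone.

Compound 1 `CCc1ccc(C(=O)Nc2ccc3nc(N4CCN(CC)CC4)cc(C)c3c2)cc1` gives 3060 nM in a functional assay on MCF7 cells (Homo sapiens) for antiproliferative activity, read by MTT assay, with a stated time of 72 h; on this read-out higher numbers stand for weaker inhibition and lower numbers for stronger inhibition. Compound 2 `CCN1CCN(c2cc(C)c3cc(NC(=O)c4ccc(OC)cc4)ccc3n2)CC1` gives 7690 nM in this assay, a step of a 2.5-fold higher number from compound 1 to compound 2 (0.40 log units; beyond the scatter). Compound 3 `CCN1CCN(c2cc(C)c3cc(NC(=O)c4ccccc4Cl)ccc3n2)CC1` reaches only a limit of the assay, > 50000 nM, and not a number. It sits at the limit of > 50000 nM in this assay, at which 1 of the 3 values shown sits, and both steps leading to it are beyond the scatter: an at least 16-fold higher number from compound 1 to compound 3 (1.21 log units; beyond the scatter) and an at least 6.5-fold higher number from compound 2 to compound 3 (0.81 log units; beyond the scatter).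

Compound 4 `CCN1CCN(c2cc(C)c3cc(NC(=O)c4ccccc4)ccc3n2)CC1` differs from compound 3 by hydrogen in place of chloro on an aromatic carbon. As far as these compounds go, the two steps that run toward the (2-chlorophenyl)carbonyl were large, so undoing part of that change is expected to give a lower number; how far compound 3 lies past its limit is unknown, which leaves the size open. Compound 4 is expected near 15000 nM, within 4000 nM to 60000 nM, an estimated step of an at least 3.3-fold lower number from compound 3 to compound 4 (0.52 log units; beyond the scatter).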

Compound 4, half-maximal inhibitory concentration: 14200 nM
Estimate against measurement, compound 4: 1.1-fold (0.02 log units) above, within the range that was stated.
By their numbers in this assay, from the lowest: compound 1; then compounds 2 and 4 (each within the scatter of the next). At a limit, above all of these: compound 3.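

Hydrogen in place of chloro, ortho to a large group, brings the series back to a measurable value, with an at least 3.5-fold lower number from compound 3 to compound 4 (0.54 log units; beyond the scatter); the loss seen with compound 3 therefore belongs to the chloro and not to the plain benzoyl. Compound 3 stands at a limit and not at a number, so this step gives only a lower bound: the limit of > 50000 nM in this assay, at which 1 of the 4 values shown sits. Hydrogen and methoxy are not separated, with a 1.8-fold higher number from compound 2 to compound 4 (0.27 log units; within the scatter), while ethyl keeps its edge, with a 4.6-fold higher number from compound 1 to compound 4 (0.67 log units; beyond the scatter).

As far as these compounds go, whether a fluoro or a methyl at the chloro's place is tolerated stays open. So does whether a propyl chain or an amine in place of the ethyl lowers the number further.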